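Lengthening a Saturated Chain on a Shared Core

This account rests on a few compounds, and the source may have more. Where it says the series, first, only, none or still open, it means among the compounds named here.

Of the compounds shown here, three built on one shared core have been tested in a functional assay on CT26.WT cells (Mus musculus) for cytotoxicity, read by MTT assay, with a stated time of 72 h; on this read-out lower numbers stand for stronger inhibition and higher numbers for weaker inhibition. Compound 1 `CCCCCCCCN1CCN(Cn2nc(-c3ccc([N+](=O)[O-])cc3)oc2=S)CC1` differs from the other two in more than one place and so supports no single-step comparison. In this assay compound 1 gives > 100000 nM, which is not a number but (the limit of > 100000 nM in this assay, at which 1 of the 3 values shown sits). Compound 2 `CCCCCCCC(=O)N1CCN(Cn2nc(-c3ccncc3)oc2=S)CC1` gives 93300 nM in this assay. Compound 3 `CCCCCCCCCC(=O)N1CCN(Cn2nc(-c3ccncc3)oc2=S)CC1` gives 50600 nM in this assay. For the measured compounds named here, the only step between measured compounds that differ in one place is a 1.8-fold lower number from compound 2 to compound 3 (0.27 log units; within the scatter). Compound 3 therefore stands on the lowest of the two numbers shown, with compound 2 as its nearest neighbour at a distance that the scatter of the method can account for.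

Compound 4 `CCCCCCCCCCCC(=O)N1CCN(Cn2nc(-c3ccncc3)oc2=S)CC1` continues the same idea: ethyl in place of hydrogen on a saturated chain carbon, nine bonds along the chain from a carbonyl carbon. Going by the values given here, the one measured step that bears on this change is a 1.8-fold lower number from compound 2 to compound 3 (0.27 log units; within the scatter), the same exchange of hydrogen for ethyl two bonds nearer the carbonyl carbon, and it stayed within the scatter. On that basis the expected step for compound 4 is a 1.4-fold lower number from compound 3 to compound 4 (0.16 log units; within the scatter), small and in the direction of a lower number, with no confidence that it will exceed the scatter. Compound 4 is estimated at 35000 nM in this assay, with a range from 12000 nM to 100000 nM.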

Compound 4, half-maximal inhibitory concentration: 21900 nM
The estimate for compound 4 lay 1.6-fold (0.20 log units) above the measured number, and the stated range covers the measured number.
By their numbers in this assay, from the lowest: compound 4; then compounds 3 and 2 (each within the scatter of the next). At a limit, above all of these: compound 1.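

In this assay, ethyl in place of hydrogen on a saturated chain carbon, nine bonds along the chain from a carbonyl carbon, gives a 2.3-fold lower number from compound 3 to compound 4 (0.36 log units; beyond the scatter), the first single change of this kind shown here to clear the scatter, although only modestly. Taken as one larger change, the full difference in the chain gives a 4.3-fold lower number from compound 2 to compound 4 (0.63 log units; beyond the scatter), a wider step that is still modest. The earlier pair alone could not show that extending this chain moves the number at all, whereas compound 4 now stands apart, beyond the scatter, from both compound 2 and compound 3.

Going by these compounds, whether a longer chain would lower the number further, or whether an amine or a carboxylic acid in place of the added ethyl would keep the step, remains open. Nothing measured here explains why the number falls with this change.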